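The source may report more compounds than this note shows. Statements on the series, on what has been measured and on what is new or still open speak of the compounds shown alone.

Of the compounds shown here, two with the same shared core have been measured so far. Compound 1, `COc1ccc(CNCCCOc2ccc(S(=O)(=O)c3c(C(C)C)cn4ccccc34)cc2)cc1OC`, gives 13 nM in a functional assay (aorta) with Rattus norvegicus as the target; on this read-out lower numbers stand for stronger inhibition and higher numbers for weaker inhibition. Compound 2, `CC(C)(C)NCCCOc1ccc(S(=O)(=O)c2c(C3CC3)cn3ccccc23)cc1`, gives 66.5 nM in this assay, which places compound 2 at the highest of the two numbers, the weaker of the pair, with compound 1 beyond the usual scatter from it. The next compound, compound 3, `CCCCN(CCCC)CCCOc1ccc(S(=O)(=O)c2c(C3CC3)cn3ccccc23)cc1`, has not yet been measured. Its structure differs from compound 2 in one place: dibutylamino in place of (tert-butyl)amino on a saturated chain carbon, three bonds along the chain from an oxygen on an aromatic ring. Going by the values given here, no measured pair shows this exact change, so its effect can only be guessed from the two values at hand. The chain end of compound 1 carries a larger group than that of compound 2 and reaches a lower number, which suggests that a larger group on the chain end may help. For compound 3 a small downward step is expected, a 1.7-fold lower number from compound 2 to compound 3 (0.22 log units; within the scatter). Compound 3 is therefore estimated at 40 nM, within a range of 12 nM to 130 nM.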

Compound 3, half-maximal inhibitory concentration: 10.9 nM
For compound 3 the middle estimate is 3.7-fold (0.56 log units) above the measured one; measured number outside the range, below it.
By their numbers in this assay, from the lowest: compounds 3 and 1 (each within the scatter of the next); then compound 2.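

Going by these compounds alone, this position on the chain responds strongly to what sits on the nitrogen: replacing (tert-butyl)amino with dibutylamino gives a 6.1-fold lower number from compound 2 to compound 3 (0.79 log units; beyond the scatter) in this assay and is the first direct reading of a change here. The step shows that the larger group, with 9 heavy atoms rather than 5, is well tolerated at this place, and that an amine without a hydrogen-bond donor can still give a low number in this assay. No supporting data are available to explain the gain.

Size and the lost donor change together in this single step, so their contributions cannot be separated. Butylamino at the same place would keep the donor while adding a longer chain, and diethylamino would lack the donor with a smaller group, so the two could help to tell these contributions apart.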